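This account rests on a few compounds, and the source may have more. Where it says the series, first, only, none or still open, it means among the compounds named here.

Compound 1 `Cc1c(Nc2ccc(C#N)cc2Cl)ncnc1OC1C2COCC1CN(S(=O)(=O)C1CC1)C2` gives 53%.
Compound 2 `Cc1c(Nc2ccc(C#N)cc2Cl)ncnc1OC1C2COCC1CN(C(=O)OC(C)(C)C)C2` gives 110%; 69% (2 entries).
Compound 3 `Cc1c(Nc2ccc(C#N)cc2Cl)ncnc1OC1C2COCC1CN(C(=O)OC1(C)CC1)C2` gives 102%.

These three compounds share a core and differ only in the group on the amine nitrogen in the ring. Within the data shown here, in a functional assay on HEK293 cells for agonist activity at Glucose-dependent insulinotropic receptor (Mus musculus), read by fluorescence and cAMP accumulation, with a stated time of 30 min (a lower number here means a smaller maximal response, a higher number a larger maximal response), compound 3 stands highest of the two single numbers, and the only measured step is a number 49 percentage points higher from compound 1 to compound 3 (beyond the scatter), which exchanges ((1-methylcyclopropyl)oxy)carbonyl for cyclopropylsulfonyl. Compound 2 is entered twice, (the several entries of compound 2 in this assay, 110%; 69% (2 entries)), and the two entries straddle the number of compound 3, so the spread of repeated measurements is considerable here.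

Compound 4 `COc1c(Nc2ccc(C#N)cc2Cl)ncnc1OC1C2COCC1CN(C(=O)OC1(C)CC1)C2` keeps the carbamate of compound 3 and changes the core itself: methoxy in place of methyl on an aromatic carbon. Among the measured compounds shown here, none of the measured steps touches this position; the single measured step concerns the amine substituent and tells nothing about a methoxy in place of methyl on the aromatic carbon. There is therefore no basis for expecting a step beyond the scatter in either direction. Compound 4 is expected to give about 100%, in a range from 70% to 120%. That estimate implies a step of a number 2 percentage points lower from compound 3 to compound 4 (within the scatter), which lies within the scatter.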

Compound 4, largest response reached (reported as percent of maximum), in percent of the reference or control that the assay uses in the Glucose-dependent insulinotropic receptor assay: 99%
For compound 4 the middle estimate is 1 percentage points above the measured one; the range from low to high includes it.
By their numbers in the Glucose-dependent insulinotropic receptor assay, from the lowest: compound 1; then compounds 4 and 3 (each within the scatter of the next).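

Among these compounds, at the aromatic carbon ortho to a (2-chloro-4-cyanophenyl)amino group, where the earlier compounds all carry methyl, methoxy in place of methyl gives in the Glucose-dependent insulinotropic receptor assay a number 3 percentage points lower from compound 3 to compound 4 (within the scatter), so this position accepts the change with no difference in maximal response that can be told from the scatter. The difference appears in another read-out: in a physicochemical assay for solubility, at pH 7.4 (on this read-out lower numbers stand for lower solubility and higher numbers for higher solubility), compound 3 gives 6000 nM and compound 4 gives 30000 nM. This single change thus leaves the maximal response in place and goes with higher solubility, something the earlier compounds, shown with no solubility value, could not reveal: the measured solubility of compound 3, 6000 nM, and of compound 4, 30000 nM, a 5.0-fold higher number (0.70 log units; beyond the scatter)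

Methoxy appears here only together with the ((1-methylcyclopropyl)oxy)carbonyl group on the ring nitrogen, so it remains open whether the same pattern would hold with the cyclopropylsulfonyl group of compound 1 or the group of compound 2. Also open, on these data alone, is how an ethoxy group, a chlorine atom or an amine on this aromatic carbon would fare for maximal response and solubility.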